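CRF receptor 1 binding: piperidinyl to pentan-3-yl swap

This account rests on a few compounds, and the source may have more. Where it says the series, first, only, none or still open, it means among the compounds named here.

Measured so far:
Compound 1 `CCN(c1nc(C)cc(C)n1)c1ccc(N(C)C)cc1C` gives 54 nM in an assay on isolated protein for binding affinity to corticotropin-releasing factor receptor 1 (Homo sapiens); a lower number here means a stronger inhibitor, a higher number a weaker inhibitor.
Compound 2 `CCN(CC)c1cc(C)nc(N(CC)c2c(Br)cc(C(C)=O)cc2OC)n1` gives 28 nM in this assay.
Compound 3 `CCN(c1nc(C)cc(N2CCCCC2)n1)c1ccc(C(C)C)cc1Br` gives 29 nM in this assay.

The three numbers lie close together. Compound 3 sits nearest to compound 2, and its gap to compound 1 also stays within the usual scatter, so nothing among the three can be called stronger or weaker than another on these data.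

Compound 4 `CCC(CC)c1cc(C)nc(N(CC)c2ccc(C(C)C)cc2Br)n1` is the next structure, not yet measured in this assay. Relative to compound 3 the change is pentan-3-yl in place of piperidin-1-yl on an aromatic carbon. Among the measured compounds shown here, no pair of measured compounds differs in this one place, so no direct precedent for the size of this step exists. Compound 2 carries a different nitrogen-linked group at the same place and gives a number close to compound 3, which supports the view that this position tolerates variation. The expectation for the step from compound 3 to compound 4 is therefore a 1.2-fold higher number from compound 3 to compound 4 (0.08 log units; within the scatter), nothing beyond the scatter in either direction. Compound 4 is expected at 35 nM, with a range from 12 nM to 100 nM.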

Compound 4, inhibition constant: 2 nM
The estimate for compound 4 lay 18-fold (1.24 log units) above the measured number; measured number outside the range, below it.
By their numbers in this assay, from the lowest: compound 4; then compounds 2, 3 and 1 (each within the scatter of the next).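

In this assay, the aromatic carbon next to the ring nitrogen proves sensitive to the group it carries: pentan-3-yl in place of piperidin-1-yl gives a 15-fold lower number from compound 3 to compound 4 (1.16 log units; beyond the scatter), a step well beyond the scatter. Among the compounds shown here, the earlier compounds offered no matched pair at this place, so this is the first direct reading of its effect. The entering group has no ring and no hydrogen-bond acceptor, but this single pair cannot show which difference matters, and no available data explain the size of the step.

Still open, going by these compounds, is whether the ring or the attached nitrogen accounts for the step; a cyclopentyl group or a morpholine ring at this place would help separate the two. A longer chain, such as heptan-4-yl, would show how far the open-chain gain extends.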